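This account rests on a few compounds, and the source may have more. Where it says the series, first, only, none or still open, it means among the compounds named here.

Compound 1 `COc1cc2c(NCC3CCC(C(=O)NO)CC3)cc(-c3ccc(C)o3)nc2cc1OCCCN1CCCC1` is the starting point. Going by the values given here, in an assay on isolated protein for inhibition of protein deacetylase HDAC6 (Homo sapiens), read by fluorescence, with a stated time of 30 min (on this read-out lower numbers stand for stronger inhibition and higher numbers for weaker inhibition), compound 1 gives 34 nM, the lowest of the two numbers so far recorded. Among the compounds with values here, its only measured neighbour is compound 2 `COc1cc2c(NCC3CCC(c4ccc(C(=O)NO)cc4)CC3)cc(-c3ccc(C)o3)nc2cc1OCCCN1CCCC1`, which in this assay gives 122 nM; the step of a 3.6-fold higher number from compound 1 to compound 2 (0.55 log units; beyond the scatter) came from swapping the hydroxamic acid on the saturated ring for the same group carried on a phenyl ring.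

Compound 3 `COc1cc2nc(-c3ccc(C)o3)cc(NCC3CCC(C(=O)NO)CC3)c2cc1OC` changes a different part of the molecule: hydrogen in place of 2-(pyrrolidin-1-yl)ethyl on a saturated chain carbon bound to an oxygen on an aromatic ring. Within the data shown here, the one measured step, from compound 1 to compound 2, alters the hydroxamic-acid end and so says nothing directly about trimming the basic side chain on the far side of the shared core; no measured pair isolates that change. With the hydroxamic acid and the rest of the core kept as in compound 1, a change of roughly the usual scatter, or only a little beyond it toward a higher number, is expected, a 1.6-fold higher number from compound 1 to compound 3 (0.21 log units; within the scatter). On that basis compound 3 is estimated at 55 nM, with a range from 20 nM to 150 nM.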

Compound 3, half-maximal inhibitory concentration: 41 nM
For compound 3 the middle estimate is 1.3-fold (0.13 log units) above the measured one; the range from low to high includes it.
By their numbers in this assay, from the lowest: compounds 1 and 3 (each within the scatter of the next); then compound 2.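

In this assay, cutting 3-(pyrrolidin-1-yl)propoxy back to methoxy gives a 1.2-fold higher number from compound 1 to compound 3 (0.08 log units; within the scatter), so the loss of the whole 2-(pyrrolidin-1-yl)ethyl part, on a saturated chain carbon bound to an oxygen on an aromatic ring, leaves no difference that this read-out can separate from scatter. The earlier step, a 3.6-fold higher number from compound 1 to compound 2 (0.55 log units; beyond the scatter), had tested only the hydroxamic-acid end, whereas this pair gives the far side of the shared core a reading of its own and shows that the pyrrolidine-bearing chain is not required for a number of this size. No measurement offered here accounts for this result.

As far as these compounds go, it remains open how this position would respond to other groups, such as a primary amine or a carboxylic acid at the end of the chain, a longer chain, or a morpholine ring in place of the pyrrolidine. Going by these compounds alone, it is equally open whether methoxy would read the same way alongside the 4-(hydroxycarbamoyl)phenyl group of compound 2, as the single pair here carries the hydroxamic acid on the saturated ring.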